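Benzyl-substituted chloro core: chloro added between ring nitrogens

The source may report more compounds than this note shows. Statements on the series, on what has been measured and on what is new or still open speak of the compounds shown alone.

Measured so far:
compound 1, `ClCc1ccc(Cn2cnc3c(Cl)ncnc32)cc1`: 2450 nM
compound 2, `ClCc1cccc(Cn2cnc3c(Cl)ncnc32)c1`: 18600 nM

In a functional assay on EKVX cells (Homo sapiens) for cytotoxicity, read by sulforhodamine B assay, with a stated time of 48 h (a lower number here means a stronger inhibitor of growth, a higher number a weaker inhibitor of growth), compound 1 gives 2450 nM and compound 2 gives 18600 nM. Compound 1 therefore stands lowest of the two numbers, and the gap to compound 2 lies beyond the scatter; the two share the same core and differ only in where the chloromethyl arm sits on the benzyl ring.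

Compound 3, `ClCc1ccc(Cn2cnc3c(Cl)nc(Cl)nc32)cc1`, keeps the benzyl arrangement of compound 1 and differs from it by chloro in place of hydrogen on an aromatic carbon, on a carbon between two ring nitrogen atoms of the shared core. Among the measured compounds shown here, no measured pair shows what this change does. The expectation is a step of modest size, if any, from compound 1, with the direction open; a change within the scatter is as likely as a small gain. The step from compound 1 to compound 3 is estimated at a 1.4-fold lower number from compound 1 to compound 3 (0.13 log units; within the scatter) in this assay. Compound 3 is thus expected to give about 1800 nM, within a range of 500 nM to 7000 nM.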

Compound 3, concentration for 50% growth inhibition: 17400 nM
The estimate for compound 3 lay 9.7-fold (0.99 log units) below the measured number, outside the stated range (above it).
By their numbers in this assay, from the lowest: compound 1; then compounds 3 and 2 (each within the scatter of the next).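

In this assay, chloro in place of hydrogen on an aromatic carbon, between two ring nitrogen atoms of the shared core, weakens growth inhibition: a 7.1-fold higher number from compound 1 to compound 3 (0.85 log units; beyond the scatter). Among the compounds shown here, this is the first step at this position, and it shows that the position is not indifferent to a single added chlorine, at least with the benzyl arrangement of compound 1. Nothing available accounts for the size or direction of this step.

On these data alone, whether the loss is specific to chloro remains open, since an amine or a methoxy group on the same carbon could give a different number. Also open, as far as these compounds go, is whether the same change would give a step of similar size with the chloromethyl arm placed as in compound 2.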